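This account rests on a few compounds, and the source may have more. Where it says the series, first, only, none or still open, it means among the compounds named here.

Measured in an ADME assay on S9 fraction from liver (Mus musculus, strain ICR/CD-1) for metabolic stability, read by LC-MS, using NADPH, with a stated time of 5 min, tested at 2 uM; on this read-out lower numbers stand for a shorter-lived compound and higher numbers for a longer-lived compound:
compound 1 `Cc1cc(Cl)cc(Cl)c1S(=O)(=O)N1CCC(N2CCC(C)CC2)CC1` gives 0.12 h.
compound 2 `CC1CCN(C2CCN(S(=O)(=O)c3cccc4ccccc34)CC2)CC1` gives < 0.0834 h, which is a limit of the assay, not a number.
compound 3 `COc1ccccc1-c1cccc(S(=O)(=O)N2CCC(N3CCC(C)CC3)CC2)c1` gives 0.25 h.

Compound 3 holds the higher of the two numbers in this assay; compound 1 sits a step below it, beyond the usual scatter, and compound 2 reaches only the limit described in the limit of < 0.0834 h in this assay, at which 1 of the 3 values shown sits.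

Compound 4 `CC1CCN(C2CCN(S(=O)(=O)c3cccc(Br)c3)CC2)CC1` is not yet measured. The change from compound 3: bromo in place of 2-methoxyphenyl on an aromatic carbon

Without a step measured between any two of these compounds, the size expected for the step in this assay is taken from the spread shown: a downward step beyond the scatter is expected, with the estimated change from compound 3 to compound 4 being a 2.5-fold lower number from compound 3 to compound 4 (0.40 log units; beyond the scatter). Compound 4 is expected at 0.1 h, within 0.05 h to 0.22 h.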

Compound 4, half-life: 0.217 h
Beside the measured number, compound 4's estimate is 2.2-fold (0.34 log units) below it; measured number inside the range.
By their numbers in this assay, from the lowest: compounds 1, 4 and 3 (each within the scatter of the next, the first and the last beyond it). At a limit, below all of these: compound 2.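

The step in this assay is a 1.2-fold lower number from compound 3 to compound 4 (0.06 log units; within the scatter) on this aromatic carbon, meta to a large group. For this pair, a whole six-membered aromatic ring of carbon with its methoxy group can therefore give way to a single bromo without a step beyond the scatter. Nothing measured here bears on why these two groups read alike.

Open, as far as these compounds go, is whether an amine or a carboxylic acid on this aromatic carbon would also stay within the scatter of compound 4.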